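Series notes: thioether replacement at the pyridine ether position

The source may report more compounds than this note shows. Statements on the series, on what has been measured and on what is new or still open speak of the compounds shown alone.

Measured so far in an assay on CHO cells for antagonist activity at transient receptor potential cation channel subfamily V member 1 (Homo sapiens), read by FLIPR; a higher number here means a weaker inhibitor, a lower number a stronger inhibitor:
Compound 1 `CCCCCCOc1nc(C(F)(F)Cl)ccc1CNC(=O)C(C)c1ccc(NS(C)(=O)=O)c(F)c1` — compound 1 gives 0.8 nM.
Compound 2 `CC(C(=O)NCc1ccc(C(F)(F)Cl)nc1OCc1ccccn1)c1ccc(NS(C)(=O)=O)c(F)c1` — compound 2 gives 4.2 nM.

Going by the values given here, compound 2 stands at the highest of the two numbers in this assay; its nearest neighbour is compound 1, and the one measured step, a 5.3-fold higher number from compound 1 to compound 2 (0.72 log units; beyond the scatter), separates them.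

Compound 3 `CC(C(=O)NCc1ccc(C(F)(F)Cl)nc1SC1CCCCC1)c1ccc(NS(C)(=O)=O)c(F)c1` is not yet measured. It differs from compound 2 in one place: cyclohexylsulfanyl in place of (pyridin-2-yl)methoxy on an aromatic carbon.

Among the compounds with values here, no measured step covers this change directly. Only a 5.3-fold higher number from compound 1 to compound 2 (0.72 log units; beyond the scatter) bears on it, and loosely: there a saturated carbon chain on the oxygen gave the lower number and pyridin-2-yl the higher one. Compound 3 brings a six-membered non-aromatic ring of carbon only, but through sulfur rather than oxygen and without the chain carbon, so that step is no more than a rough guide. On that basis a modest move back toward the number of compound 1 is expected for compound 3, with wide uncertainty, as a 2.1-fold lower number from compound 2 to compound 3 (0.32 log units; beyond the scatter).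

In this assay compound 3 is estimated at 2 nM, within a range of 0.5 nM to 8 nM.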

Compound 3, inhibition constant: 3 nM
For compound 3 the middle estimate is 1.5-fold (0.18 log units) below the measured one, and the stated range covers the measured number.
By their numbers in this assay, from the lowest: compound 1; then compounds 3 and 2 (each within the scatter of the next).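

In this assay, the aromatic carbon next to the ring nitrogen takes cyclohexylsulfanyl in place of (pyridin-2-yl)methoxy with a 1.4-fold lower number from compound 2 to compound 3 (0.15 log units; within the scatter), so these two groups, which differ in linking atom and ring, cannot be told apart at this position in this read-out. Against hexyloxy, the same cyclohexylsulfanyl group gives a 3.8-fold higher number from compound 1 to compound 3 (0.57 log units; beyond the scatter), which leaves compound 1 with the lowest number of the three, its steps to both of the others lying beyond the scatter. No measurement is available that bears on the reason for these differences.

The step from hexyloxy to cyclohexylsulfanyl changes the linking atom and the attached carbon group together, so the compounds shown do not separate the effect of sulfur from that of the ring; cyclohexyloxy and hexylsulfanyl would each isolate one of those two changes. Also open is how this position responds to a group carrying an amine or a carboxylic acid at the end of a saturated chain, since the groups shown here hold only carbon rings, a carbon chain or a pyridine.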